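Thioether side-chain variation on the shared core

A few compounds are considered here, and "the series" means these few. Any claim that something is new, unique, unknown or untested is made for them only; others in the source may bear on it.

Going by the values given here, compound 1 `Cc1cc(Nc2cc(-c3ccccc3)[nH]n2)n2nc(SCc3ccc(C(F)(F)F)cc3)nc2n1` is the only member of the series with an actual number in a functional assay on PC-9 cells (Homo sapiens) for inhibition, read by MTT assay, with a stated time of 72 h; a lower number here means a stronger inhibitor, a higher number a weaker inhibitor; in this assay compound 1 gives 4240 nM. Among the compounds with values here, compound 2 `Cc1nc2nc(SCc3ccc(Cl)cc3)nn2c(Nc2cc(-c3ccccc3)[nH]n2)c1C` differs from compound 1 in more than one place, so no single step between them can be read. In this assay compound 2 gives > 50000 nM, which is a limit of the assay and not a number (the limit of > 50000 nM in this assay, at which 1 of the 2 values shown sits). Within the data shown here, with no pair of measured compounds differing in one place, no measured step is available to anchor any expectation.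

Compound 3 `Cc1cc(Nc2cc(-c3ccccc3)[nH]n2)n2nc(SCC(=O)c3ccccc3)nc2n1` has not yet been measured. It differs from compound 1 in one place: benzoyl in place of 4-(trifluoromethyl)phenyl on a saturated chain carbon bound to a sulfur. Cut one bond further out, the change reads 4-(trifluoromethyl)benzyl to benzoylmethyl, so one hydrogen-bond acceptor enters the side chain.

Without a measured step to point to, the step of a 1.9-fold higher number from compound 1 to compound 3 (0.28 log units; within the scatter) is expected to be modest and, if anything, toward weaker inhibition, though it may sit within the scatter. Compound 3 is estimated at 8000 nM, with a range from 2500 nM to 30000 nM.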

Compound 3, half-maximal inhibitory concentration: 4450 nM
Beside the measured number, compound 3's estimate is 1.8-fold (0.25 log units) above it; measured number inside the range.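

In this assay the series now has its first readable step, a 1.0-fold higher number from compound 1 to compound 3 (0.02 log units; within the scatter), so benzoyl in place of 4-(trifluoromethyl)phenyl on a saturated chain carbon bound to a sulfur stays within the scatter, even though a hydrogen-bond acceptor enters the side chain and the trifluoromethyl group leaves it. In this assay, 4-(trifluoromethyl)benzyl and benzoylmethyl therefore cannot be told apart at this place on the shared core, a reading that rests on this single pair alone. No measurement shown bears on why the step is so small.

The steps involving compound 2 cannot be read, and its value of > 50000 nM is a limit of the assay and not a number. On these data alone, whether an amine, a carboxylic acid or a longer chain in place of these side chains would move the number beyond the scatter remains open, as does whether the same change would stay within the scatter on a core other than that of compound 1.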